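The source may hold more compounds than are shown below. What is called first, only, known or untested is meant among the compounds shown, and "the series" means these compounds.

Measured so far:
compound 1 `CN(Cc1cn(CC(O)COC(=O)C2CCCCC2)nn1)CC1CCCCC1`, in an assay on nucleic acid for inhibition of Nucleic Acid, read by fluorescence, tested at 100 uM (on this read-out higher numbers stand for more inhibition at the one concentration tested (going by the name of the read-out) and lower numbers for less inhibition), compound 1 gives 18%
compound 2 `CCCCC(O)Cn1cc(CN(C)CC2CCCCC2)nn1`, compound 2 gives 47%

Going by the values given here, compound 2 stands highest of the two numbers; the one step known, a number 29 percentage points higher from compound 1 to compound 2 (beyond the scatter), changes a different part of the molecule and says nothing about the amine side. Compound 3 `CCCCC(O)Cn1cc(CN(C)CCCc2ccccc2)nn1` differs from compound 2 by phenethyl in place of cyclohexyl on a saturated chain carbon bound to an amine nitrogen. Among the compounds with values here, no measured step touches this position, so the direction and size of the change in this assay are open; the estimate is a step of a number 5 percentage points lower from compound 2 to compound 3 (within the scatter), kept close to compound 2 with a wide range. Compound 3 is therefore expected to give 42%, between 15% and 70%.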

Compound 3, a percentage reported as inhibition, at one concentration (the size of the read-out at that concentration, not a potency): 37%
Compound 3: the middle estimate sits 5 percentage points above what was measured; the range from low to high includes it.
By their numbers in this assay, from the lowest: compound 1; then compounds 3 and 2 (each within the scatter of the next).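

In this assay, going by these compounds alone, the first measured change on the saturated chain carbon bound to an amine nitrogen, phenethyl in place of cyclohexyl, gives a number 10 percentage points lower from compound 2 to compound 3 (within the scatter). This position therefore takes an aromatic ring in place of a non-aromatic one, with more heavy atoms in the group, without a difference that the read-out can separate from scatter. No available evidence accounts for this result.

Still open, as far as these compounds go, is whether benzyl, a plain butyl chain or a pyridine ring at this place would read apart from cyclohexyl and phenethyl. Also open, from the compounds shown here alone, is whether the same exchange would read alike with (cyclohexylcarbonyl)oxy in place of propyl.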